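The source may hold more compounds than are shown below. What is called first, only, known or untested is meant among the compounds shown, and "the series" means these compounds.

Compound 1 `CC(=O)Nc1ccc(S(=O)(=O)NNC(=O)c2cccnc2Nc2ccc(Cl)cc2)cc1` and compound 2 `O=C(NNS(=O)(=O)c1ccc(F)cc1)c1cccnc1Nc1ccc(Cl)cc1Cl` share one core and have both been run in a functional assay on CAKI-1 cells (Homo sapiens) for antiproliferative activity; a lower number here means a stronger inhibitor of growth, a higher number a weaker inhibitor of growth. For compound 1 the result is only a limit of the assay, > 100000 nM. For compound 2 the result is likewise only a limit, > 100000 nM. Compound 1 therefore stands at the limit of > 100000 nM in this assay, at which 2 of the 2 values shown sit, with no number to rank it. Compound 3 `O=C(NNS(=O)(=O)c1ccc(Cl)cc1Cl)c1cccnc1Nc1ccc(Cl)cc1` differs from compound 1 by 2,4-dichlorophenyl in place of 4-acetamidophenyl on a sulfonyl sulfur. Within the data shown here, no measured step covers this change; since compound 1 sits at the limit of > 100000 nM in this assay, at which 2 of the 2 values shown sit, no move beyond the scatter is expected, and the step from compound 1 to compound 3 is estimated as a number no higher from compound 1 to compound 3 (the limit leaves the size open). Compound 3 is expected at 100000 nM, between 30000 nM and 300000 nM, most likely again only a limit.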

Compound 3, concentration for total growth inhibition: 58900 nM
Beside the measured number, compound 3's estimate is 1.7-fold (0.23 log units) above it; the measured number falls inside the stated range.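

In this assay, among these compounds, compound 3 gives the first real number, so a sulfonyl sulfur bearing 2,4-dichlorophenyl yields a readable result where 4-acetamidophenyl yielded only a limit. The change amounts to an at least 1.6-fold lower number from compound 1 to compound 3 (0.22 log units; that floor lies within the scatter). Its true size stays open because the result for compound 1 is only a limit: the limit of > 100000 nM in this assay, at which 2 of the 3 values shown sit.

Compound 2 differs from compound 3 in more than one place, so it offers no direct comparison. On these data alone, how an unsubstituted phenyl, a 4-methoxyphenyl or a cyclohexyl on the sulfonyl sulfur would read in this assay remains open.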